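Weak cytotoxicity and an amide side chain

A few compounds are considered here, and "the series" means these few. Any claim that something is new, unique, unknown or untested is made for them only; others in the source may bear on it.

Measured compounds:
- compound 1 `CC1=NN(C(=O)CN2CCN(C)CC2)C(c2ccccc2O)C1`: "not active" (no number reported) in a functional assay on HepG2 cells (Homo sapiens) for cytotoxicity, read by MTT assay, with a stated time of 48 h; on this read-out lower numbers stand for stronger inhibition and higher numbers for weaker inhibition
- compound 2 `CCN(CC)CC(=O)N1N=C(C)CC1c1ccccc1OC(C)=O`: 33200 nM
- compound 3 `Cc1ccc(C(=O)N2N=C(c3cc4ccccc4oc3=O)CC2c2ccccc2)cc1`: 52300 nM

Compound 3 has the highest of the two reported numbers in this assay; its nearest neighbour is compound 2, and the gap between them lies within the usual scatter, so the two values cannot be ranked. Compound 1 gave no number at all. The step to compound 4 `CCN(CC)C1CCN(CC(=O)N2N=C(c3cc4ccccc4oc3=O)CC2c2ccccc2)CC1` changes the group on the carbonyl carbon: (4-(diethylamino)piperidin-1-yl)methyl in place of 4-methylphenyl on a carbonyl carbon. Among the compounds with values here, the only other compound with a diethylamino group on such a side chain, compound 2, also sits in the weak range, so no step beyond the scatter is expected in either direction. The step from compound 3 to compound 4 is expected to be a 1.2-fold lower number from compound 3 to compound 4 (0.07 log units; within the scatter). For compound 4 the estimate in this assay is 45000 nM, with a range from 15000 nM to 150000 nM.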

Compound 4, half-maximal inhibitory concentration: 19300 nM
For compound 4 the middle estimate is 2.3-fold (0.37 log units) above the measured one; measured number inside the range.
By their numbers in this assay, from the lowest: compounds 4, 2 and 3 (each within the scatter of the next, the first and the last beyond it).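

In this assay, within the data shown here, the group on the carbonyl carbon turns out to matter: (4-(diethylamino)piperidin-1-yl)methyl in place of 4-methylphenyl gives a 2.7-fold lower number from compound 3 to compound 4 (0.43 log units; beyond the scatter), the only step here that can be read. The step is modest, and compound 4 remains a weak inhibitor on this read-out. No measurement available here explains the step.

The compounds shown leave open whether the piperidine ring or the diethylamino group carries the step. From the compounds shown here alone, how a morpholin-4-ylmethyl group or a carboxylic acid would behave at this place also remains unknown.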